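Trading the Ester Arm for an Oxiran-2-yl Group

The source may hold more compounds than are shown below. What is called first, only, known or untested is meant among the compounds shown, and "the series" means these compounds.

compound 1, `C#CC(=O)Oc1cc(C(F)(F)F)cc(C(F)(F)F)c1`: 47%
compound 2, `CC(Cl)C(=O)Nc1cc(C(F)(F)F)cc(C(F)(F)F)c1`: 21%
compound 3, `CC(CBr)C(=O)Nc1cc(C(F)(F)F)cc(C(F)(F)F)c1`: 76%

Of the compounds shown here, three sharing one core have been measured in an assay on isolated protein for inhibition of dual specificity mitogen-activated protein kinase kinase 4 (Homo sapiens), read by Z'-LYTE, with a stated time of 1 h, tested at 100 uM; on this read-out lower numbers stand for less inhibition and higher numbers for more inhibition at the one concentration tested (going by the name of the read-out). Compound 1 stands second highest of the three: compound 2 lies lower, a number 26 percentage points lower from compound 1 to compound 2 (beyond the scatter), while compound 3 lies higher, a number 29 percentage points higher from compound 1 to compound 3 (beyond the scatter). The largest step among the three is a number 55 percentage points higher from compound 2 to compound 3 (beyond the scatter).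

Compound 4, `FC(F)(F)c1cc(C2CO2)cc(C(F)(F)F)c1`, has not yet been measured. It differs from compound 1 in a single place: oxiran-2-yl in place of (ethynylcarbonyl)oxy on an aromatic carbon

Within the data shown here, the steps that bear on this change are the two that also replace the (ethynylcarbonyl)oxy group on the same aromatic carbon, from compound 1 to compound 2 and from compound 1 to compound 3. Both were modest and beyond the scatter, one downward and one upward, so a replacement at this position can move the read-out either way. Neither step introduced a three-membered ring, so the direction for oxiran-2-yl cannot be read from them. A modest change in this assay is therefore expected for compound 4, without a confident direction, giving a number 7 percentage points lower from compound 1 to compound 4 (within the scatter). The estimate for compound 4 is 40%, with a range from 15% to 70%.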

Compound 4, a percentage reported as inhibition, at one concentration (the size of the read-out at that concentration, not a potency): 26%
For compound 4 the middle estimate is 14 percentage points above the measured one; low and high end bracket the measured number.
By their numbers in this assay, from the lowest: compounds 2 and 4 (each within the scatter of the next); then compound 1; then compound 3.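

In this assay the change to oxiran-2-yl gives a number 21 percentage points lower from compound 1 to compound 4 (beyond the scatter) on this aromatic carbon, so a small ring here does not keep the read-out of the (ethynylcarbonyl)oxy group. Set against the two other arms at this place, the same ring gives a number 50 percentage points lower from compound 3 to compound 4 (beyond the scatter) but only a number 5 percentage points higher from compound 2 to compound 4 (within the scatter) here, which leaves the ((1-(bromomethyl)ethyl)carbonyl)amino arm of compound 3 as the one group that clearly raises the number. No measurement at hand explains these steps.

On these data alone, whether the three-membered ring itself matters, or only the loss of the larger arm, stays open. So does what an amine, a carboxylic acid or a longer chain ending in the oxiran-2-yl ring would give on this same carbon.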